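Swapping the aryl group on a thiosemicarbazone: compound 1 to compound 4

This account rests on a few compounds, and the source may have more. Where it says the series, first, only, none or still open, it means among the compounds named here.

Three thiosemicarbazones built on a shared core have so far been measured in a functional assay on HeLa cells (Homo sapiens) for antiproliferative activity, read by sulforhodamine B assay, with a stated time of 72 h; on this read-out higher numbers stand for weaker inhibition and lower numbers for stronger inhibition. Compound 1, `COc1cccc(NC(=S)N/N=C/c2ccc3ccccc3n2)c1`, gives 74500 nM and stands at the weak end of the set: its number is the highest of the three, and both neighbours lie well beyond the usual scatter. Compound 2, `CC(C)c1cccc(C(C)C)c1NC(=S)N/N=C/c1ccc2ccccc2n1`, gives 16400 nM in this assay, and compound 3, `FC(F)(F)c1ccccc1NC(=S)N/N=C/c1ccc2ccccc2n1`, gives 18800 nM; these two sit close to each other, so no order between them can be claimed.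

The next compound differs from compound 1 in a single place. Compound 4 is `Cc1ccc(NC(=S)N/N=C/c2ccc3ccccc3n2)cc1`, and the change is 4-methylphenyl in place of 3-methoxyphenyl on an amide-type nitrogen. Going by the values given here, no measured pair in this set shares exactly this change, so its size can only be judged from the fact that both other variations of the group on the amide-type nitrogen gave lower numbers than compound 1.

On that basis the author expects a moderate step toward lower numbers, a 2.3-fold lower number from compound 1 to compound 4 (0.37 log units; beyond the scatter), likely beyond the scatter but not approaching the gap seen from compound 1 to compound 3, given that compound 3 gives 18800 nM. Compound 4 is therefore estimated at 32000 nM in this assay, within a range of 12000 nM to 90000 nM.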

Compound 4, half-maximal inhibitory concentration: 86000 nM
Beside the measured number, compound 4's estimate is 2.7-fold (0.43 log units) below it; the range from low to high includes it.
By their numbers in this assay, from the lowest: compounds 2 and 3 (each within the scatter of the next); then compounds 1 and 4 (each within the scatter of the next).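

In this assay, putting 4-methylphenyl in place of 3-methoxyphenyl on the amide-type nitrogen gives a 1.2-fold higher number from compound 1 to compound 4 (0.06 log units; within the scatter), so this change leaves the read-out effectively unchanged. Going by these compounds alone, the earlier compounds showed only that the number can differ with the aryl group at this position; this pair shows that not every exchange there moves it, even though the entering group has 0 hydrogen-bond acceptors and the leaving group has 1. No measurement bears on this result, so the data offer no account of why these two groups give matching numbers.

The two group names differ both in the substituent and in its numbered place on the ring, and the compounds shown do not separate these two changes, so a 3-methylphenyl or a 4-methoxyphenyl group on the same nitrogen remains an open case. Going by these compounds, it also remains open how an aryl group carrying an amine or a carboxylic acid, or a longer chain on the amide-type nitrogen, would read in this assay.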